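A few compounds are considered here, and "the series" means these few. Any claim that something is new, unique, unknown or untested is made for them only; others in the source may bear on it.

Compound 2 `COc1ccc(Cl)cc1S(=O)(=O)Nc1cncc(-c2ccc(Cl)cc2)c1` gives 198 nM in an assay on isolated protein for inhibition of alkaline phosphatase, tissue-nonspecific isozyme (Homo sapiens); a lower number here means a stronger inhibitor, a higher number a weaker inhibitor. Among the three compounds measured it holds the middle place: compound 1 `COc1ccc(C(N)=O)cc1S(=O)(=O)Nc1cccnc1` gives 1490 nM and sits well above it, while compound 3 `COc1ccc(Cl)cc1S(=O)(=O)Nc1cnc2ccccc2c1` gives 6 nM and sits far below it, both gaps beyond the usual scatter. Compound 4 `CCNC(=O)c1cncc(NS(=O)(=O)c2cc(Cl)ccc2OC)c1` has not yet been measured. It differs from compound 2 in one place: ethylcarbamoyl in place of 4-chlorophenyl on an aromatic carbon. Within the data shown here, no measured pair isolates this change, so any expectation rests on the set as a whole. Among the measured compounds shown here, compound 4 is expected to be weaker than compound 2 in this assay, by a step of a 3.5-fold higher number from compound 2 to compound 4 (0.55 log units; beyond the scatter), since the only other compound without a second ring, compound 1, gives 1490 nM. The estimate for compound 4 is 700 nM, ranging from 200 nM to 2500 nM.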

Compound 4, half-maximal inhibitory concentration: 193 nM
Compound 4: middle estimate off by 3.6-fold (0.56 log units), on the high side; the whole stated range lies above it.
By their numbers in this assay, from the lowest: compound 3; then compounds 4 and 2 (each within the scatter of the next); then compound 1.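

Putting ethylcarbamoyl in place of 4-chlorophenyl gives a 1.0-fold lower number from compound 2 to compound 4 (0.01 log units; within the scatter) in this assay and so leaves the inhibition unchanged within the scatter. At this position, then, a group with no ring serves as well as one with a six-membered aromatic ring of carbon only, although the two share little beyond their place on the core. Nothing measured here accounts for this match. Still open, from the compounds shown here alone, is whether the amide hydrogen matters, and what a carboxylic acid, an amine or a longer chain would give at this position.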